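Swapping the aryl group on the top compound of the series

The source may hold more compounds than are shown below. What is called first, only, known or untested is meant among the compounds shown, and "the series" means these compounds.

Of the compounds shown here, three have numbers so far in a functional assay on COLO 205 cells (Homo sapiens) for inhibition, read by sulforhodamine B assay, with a stated time of 48 h, tested at 50 uM; a lower number here means less inhibition of growth, a higher number more inhibition of growth at the concentration tested. Compound 1 (`COc1cc(/C=C/C(=O)/C=C/c2cccc3ccccc23)ccc1OCc1cn(CCOc2cc(=O)oc3ccccc23)nn1`) gives 85% and is the highest of the three. Compound 2 (`COc1cc(/C=C/C(=O)/C=C/c2ccco2)ccc1OCc1cn(CCCOc2cc(=O)oc3ccccc23)nn1`) gives 59% and compound 3 (`COc1cccc(/C=C/C(=O)/C=C/c2ccc(OCc3cn(CCCCCOc4cc(=O)oc5ccccc45)nn3)c(OC)c2)c1`) gives 34% and both lie beyond the scatter under compound 1. For the measured compounds named here, these compounds differ from each other in more than one place, so no single-change step has been measured yet.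

Compound 4 (`COc1cccc(/C=C/C(=O)/C=C/c2ccc(OCc3cn(CCOc4cc(=O)oc5ccccc45)nn3)c(OC)c2)c1`) departs from compound 1 in one place (3-methoxyphenyl in place of naphthalen-1-yl on a double-bonded chain carbon bound to a double-bonded chain carbon), with 3-methoxyphenyl in place of naphthalen-1-yl on a double-bonded chain carbon bound to a double-bonded chain carbon. Going by the values given here, compound 3 at 34% is the one measured compound with the 3-methoxyphenyl group, which hints at a loss, although it also differs from compound 1 elsewhere. A drop beyond the scatter is expected in this assay, estimated as a number 23 percentage points lower from compound 1 to compound 4 (beyond the scatter) on thin evidence. Compound 4 is estimated at 62% with an expected range of 42% to 82% in this read-out.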

Compound 4, percent growth inhibition at one concentration: 69%
Beside the measured number, compound 4's estimate is 7 percentage points below it, and the stated range covers the measured number.
By their numbers in this assay, from the lowest: compound 3; then compounds 2 and 4 (each within the scatter of the next); then compound 1.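

In this assay, for the compounds shown here, a number 16 percentage points lower from compound 1 to compound 4 (beyond the scatter) is the first single-change reading at this place, on a double-bonded chain carbon bound to a double-bonded chain carbon, and it is a modest loss. Compound 4 keeps 69% with 3-methoxyphenyl, so on this core the two-ring naphthalen-1-yl group is not needed for substantial growth inhibition at the concentration tested, though it gives the higher number. The step swaps one ring for two and adds a methoxy oxygen together, and no measurement at hand accounts for the drop.

Still open, going by these compounds, is whether the loss follows the missing ring or the methoxy group, a question that plain phenyl at this place would address. Also open, on these data alone, is how a dimethylamino or carboxylic acid substituent on that phenyl ring would read.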